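Trimethoxyphenyl for chlorophenyl at the triazole benzyl position

This account rests on a few compounds, and the source may have more. Where it says the series, first, only, none or still open, it means among the compounds named here.

Three piperazine dithiocarbamates have been measured in a functional assay on MCF7 cells (Homo sapiens) for inhibition, read by MTT assay, with a stated time of 72 h; on this read-out higher numbers stand for weaker inhibition and lower numbers for stronger inhibition. Compound 2 `O=C(OCc1ccccc1)N1CCN(C(=S)SCc2cn(Cc3ccc(Cl)cc3)nn2)CC1` gives 27500 nM. Compound 3 `Fc1ccccc1Cn1cc(CSC(=S)N2CCNCC2)nn1` gives 33200 nM, which lies within the scatter of the number for compound 2. Compound 1 `CC(C)(C)OC(=O)N1CCN(C(=S)SCc2cn(-c3ccccc3F)nn2)CC1` gives 89600 nM, a number beyond the scatter above that of compound 2, so compound 2 and compound 1 are separated, while compound 2 and compound 3 are not. Among the measured compounds shown here, no pair of measured compounds differs in only one place, so no step size has been observed.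

Compound 4 `COc1cc(Cn2cc(CSC(=S)N3CCN(C(=O)OCc4ccccc4)CC3)nn2)cc(OC)c1OC` is not yet measured. It differs from compound 2 as follows: 3,4,5-trimethoxyphenyl in place of 4-chlorophenyl on a saturated chain carbon bound to an aromatic nitrogen. For the measured compounds named here, with no measured step to guide the size of such a change, the expectation is a modest move toward stronger inhibition at most, or none beyond the scatter. Compound 4 is therefore expected to give about 15000 nM, with a range from 5000 nM to 45000 nM. The estimated step from compound 2 to compound 4 is a 1.8-fold lower number from compound 2 to compound 4 (0.26 log units; within the scatter).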

Compound 4, half-maximal inhibitory concentration: > 128000 nM
Compound 4: no number, only a limit; the forecaster's own chance of this, stated with the estimate: 5%; middle value at least 8.5-fold (0.93 log units) from the limit.
By their numbers in this assay, from the lowest: compounds 2 and 3 (each within the scatter of the next); then compound 1. At a limit, above all of these: compound 4.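

Compound 4 has no number in this assay, only a limit: the limit of > 128000 nM in this assay, at which 1 of the 4 values shown sits. The series now has its first step between compounds that differ in one place, as 3,4,5-trimethoxyphenyl replaces 4-chlorophenyl on a saturated chain carbon bound to an aromatic nitrogen: an at least 4.6-fold higher number from compound 2 to compound 4 (0.66 log units; beyond the scatter). With the rest of compound 2 unchanged, the group at this position therefore matters in this assay, and this change moves toward weaker inhibition by an amount that the limit leaves without an upper bound.

The step does not separate the loss of the chlorine from the entry of the methoxy groups. From the compounds shown here alone, whether the position tolerates any oxygen substituent remains open, and a 4-methoxyphenyl or an unsubstituted phenyl at the same place would bear on both questions.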